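Removing a methyl from the oxygen: compound 2 to compound 3

The source may hold more compounds than are shown below. What is called first, only, known or untested is meant among the compounds shown, and "the series" means these compounds.

Of the compounds shown here, two with a shared core have been measured. Compound 1 `Cc1cc(O)cc(-c2nn(CC#N)cc2-c2ccnc(-c3ccc(Oc4ccccc4)cc3)c2)c1` gives 6020 nM in a functional assay on K562 cells (Homo sapiens) for inhibition, read by sulforhodamine B assay, with a stated time of 48 h; on this read-out higher numbers stand for weaker inhibition of growth and lower numbers for stronger inhibition of growth. Compound 2 `COc1cc(C)cc(-c2nn(CC#N)cc2-c2ccnc(-c3ccc(N(C)C)cc3)c2)c1` reaches only the limit of this assay, giving > 100000 nM; this is a limit and not a number, and it is where compound 2 stands on the numbers shown (the limit of > 100000 nM in this assay, at which 1 of the 2 values shown sits). Compound 3 `Cc1cc(O)cc(-c2nn(CC#N)cc2-c2ccnc(-c3ccc(N(C)C)cc3)c2)c1` has not been measured in this assay. It differs from compound 2 by hydrogen in place of methyl on an oxygen on an aromatic ring, the same change read one bond further out as methoxy to hydroxy. Among the compounds with values here, no step between two measured compounds covers this change, so the direction is expected rather than known; compound 1, which also carries the hydroxy group, gives 6020 nM, which leaves room for a move towards stronger inhibition. The expected step is an at least 2.5-fold lower number from compound 2 to compound 3 (0.39 log units; beyond the scatter). Compound 3 is estimated at 40000 nM, between 8000 nM and 200000 nM.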

Compound 3, concentration for total growth inhibition: 32800 nM
Compound 3: middle estimate off by 1.2-fold (0.09 log units), on the high side; low and high end bracket the measured number.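

In this assay the change from methoxy to hydroxy gives an at least 3.0-fold lower number from compound 2 to compound 3 (0.48 log units; beyond the scatter) and so brings this dimethylamino compound to a measurable number. From the compounds shown here alone, the full size of that step stays unknown, as the value of compound 2 is a limit and not a number: the limit of > 100000 nM in this assay, at which 1 of the 3 values shown sits. With the hydroxy group held constant, dimethylamino in place of phenoxy on an aromatic carbon gives a 5.4-fold higher number from compound 1 to compound 3 (0.74 log units; beyond the scatter) and shows that the outcome also depends on that second place.

Going by these compounds, the methoxy to hydroxy step is read only in the dimethylamino compounds, so it remains open whether the phenoxy compound would respond in the same way. Also open, on these data alone, is how an amine or an ethoxy group would compare with hydroxy on this aromatic ring.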